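Chloro to bromo on the shared core

The source may hold more compounds than are shown below. What is called first, only, known or untested is meant among the compounds shown, and "the series" means these compounds.

Compound 1 `C[C@H]1[C@H](O)[C@@H](CO)O[C@H]1n1cc(F)c(=O)[nH]c1=O` gives > 100 ug/mL (a limit)
Compound 2 `C[C@H]1[C@H](O)[C@@H](CO)O[C@H]1n1cc(Cl)c(=O)[nH]c1=O` gives > 100 ug/mL (a limit)

In a functional assay on NC-37 cells (Homo sapiens) for cytotoxicity (on this read-out higher numbers stand for lower toxicity in this test and lower numbers for higher toxicity in this test), compound 2 gives > 100 ug/mL as a limit and not a number. Going by the values given here, the same holds across the series so far: the limit of > 100 ug/mL in this assay, at which 2 of the 2 values shown sit.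

Compound 3 `C[C@H]1[C@H](O)[C@@H](CO)O[C@H]1n1cc(Br)c(=O)[nH]c1=O` differs from compound 2 as follows: bromo in place of chloro on an aromatic carbon. Among the compounds with values here, the only measured step bearing on this is a step that the two limits leave unreadable from compound 1 to compound 2, chloro in place of fluoro on an aromatic carbon. It gives no size to carry over, so no step beyond the scatter and no direction is expected in this assay. The estimated step is a step that the limit leaves unreadable from compound 2 to compound 3 and should stay small. Compound 3 is expected at 120 ug/mL, with an estimated range of 50 ug/mL to 280 ug/mL and a limit as the likeliest report.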

Compound 3, half-maximal cytotoxic concentration: > 100 ug/mL
Compound 3: only a limit was reported; the forecaster's own chance of this, stated with the estimate: 75%; the middle value lies beyond the limit too.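

With compound 3 also reported as a limit in this assay, no step can be read among compound 1, compound 2 and compound 3: the limit of > 100 ug/mL in this assay, at which 3 of the 3 values shown sit.

In this assay, as far as these compounds go, it remains open whether fluoro, chloro and bromo on the shared core differ at all.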